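The source may hold more compounds than are shown below. What is called first, only, known or untested is meant among the compounds shown, and "the series" means these compounds.

The study compares three measured compounds that share one core and differ only in the group on the carbonyl carbon. Compound 1 `O=C(Nc1sc2c(c1C(=O)NNc1ccccc1)CCCCC2)NS(=O)(=O)c1ccccc1` gives 18600 nM in a functional assay on cells (Leukemia cell, Homo sapiens) for inhibition, with a stated time of 48 h; on this read-out higher numbers stand for weaker inhibition of growth and lower numbers for stronger inhibition of growth. Compound 2 `O=C(Nc1sc2c(c1C(=O)NNc1ccc(Cl)cc1)CCCCC2)NS(=O)(=O)c1ccccc1` gives 30600 nM in this assay, and the step of a 1.6-fold higher number from compound 1 to compound 2 (0.22 log units; within the scatter) is small. Compound 3 `O=C(Nc1sc2c(c1C(=O)N1CCN(c3ccccc3)CC1)CCCCC2)NS(=O)(=O)c1ccccc1` reaches only the limit of this assay and gives > 100000 nM. Compound 3 therefore stands at the weak end of what the numbers show, and the limit of > 100000 nM in this assay, at which 1 of the 3 values shown sits, means that no number for it is known, only that limit.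

The unmeasured compound 4 `O=C(Nc1sc2c(c1C(=O)NNc1ccc(Br)cc1)CCCCC2)NS(=O)(=O)c1ccccc1` carries the change ((4-bromophenyl)amino)amino in place of 4-phenylpiperazin-1-yl on a carbonyl carbon relative to compound 3. The measured steps that bear on it run the other way: an at least 5.3-fold higher number from compound 1 to compound 3 (0.73 log units; beyond the scatter) and an at least 3.2-fold higher number from compound 2 to compound 3 (0.51 log units; beyond the scatter), both beyond the scatter. Compound 4 in its group on the carbonyl carbon resembles compound 1 and compound 2 far more than compound 3, so in this assay a step in the opposite direction, towards stronger inhibition of growth, is expected, of the size an at least 3.3-fold lower number from compound 3 to compound 4 (0.52 log units; beyond the scatter). Compound 4 is accordingly estimated at 30000 nM in this assay, with a range from 12000 nM to 80000 nM.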

Compound 4, concentration for 50% growth inhibition: > 100000 nM
Compound 4: no number, only a limit; the forecaster's own chance of this, stated with the estimate: 15%; at least 3.3-fold (0.52 log units) between middle value and limit.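

Until now, only 4-phenylpiperazin-1-yl on the carbonyl carbon had taken a compound to the limit of this assay in this series, while chloro in place of hydrogen on the aromatic carbon had produced only a 1.6-fold higher number from compound 1 to compound 2 (0.22 log units; within the scatter) on the ring of the group. Compound 4 now reaches that limit with the hydrazide-type link on the carbonyl carbon kept, and the change on the aromatic carbon gives an at least 3.2-fold higher number from compound 2 to compound 4 (0.51 log units; beyond the scatter) for bromo in place of chloro and an at least 5.3-fold higher number from compound 1 to compound 4 (0.73 log units; beyond the scatter) for bromo in place of hydrogen. The presence of this link is therefore not enough on its own to keep a measurable value in this assay, and among compound 1, compound 2 and compound 4 the outcome differs with the atom on that aromatic carbon.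

Going by these compounds, whether methyl, methoxy or fluoro on that aromatic carbon would stay measurable as chloro does or go to the limit as bromo does remains open. Compound 3 and compound 4 cannot be ranked against each other, because each stands only at a limit and not at a number: the limit of > 100000 nM in this assay, at which 2 of the 4 values shown sit.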